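Phenoxy for phenyl on the benzylic carbon

The source may report more compounds than this note shows. Statements on the series, on what has been measured and on what is new or still open speak of the compounds shown alone.

Three compounds sharing one core were measured in an assay on CHO cells for displacement of a labelled ligand from prostaglandin E2 receptor EP3 subtype (Mus musculus), read by scintillation counting; on this read-out lower numbers stand for stronger inhibition and higher numbers for weaker inhibition. Compound 1 `O=C(O)/C=C/c1ccc(Cn2cccn2)cc1OCCc1ccc2ccccc2c1` gives 12 nM. Compound 2 `O=C(O)/C=C/c1ccc(Cn2ccnc2)cc1OCCc1ccc2ccccc2c1` gives 16 nM. Compound 3 `O=C(O)/C=C/c1ccc(Cc2ccccc2)cc1OCCc1ccc2ccccc2c1` gives 130 nM, the highest number of the three, so it stands as the weakest binder in the set. The two steps that reach it are an 11-fold higher number from compound 1 to compound 3 (1.03 log units; beyond the scatter) and an 8.1-fold higher number from compound 2 to compound 3 (0.91 log units; beyond the scatter), whereas a 1.3-fold higher number from compound 1 to compound 2 (0.12 log units; within the scatter). Compound 4 `O=C(O)/C=C/c1ccc(COc2ccccc2)cc1OCCc1ccc2ccccc2c1` differs from compound 3 in one place: phenoxy in place of phenyl on a saturated chain carbon bound to an aromatic carbon. Going by the values given here, no measured step exchanges phenyl for phenoxy. The steps that touch compound 3 both put phenyl in place of an azole and both raised the number well beyond the scatter. A phenoxy brings one hydrogen-bond acceptor but is neither 1H-pyrazol-1-yl nor 1H-imidazol-1-yl, so at most a partial recovery is expected. Compound 4 is therefore expected to give 90 nM in this assay, within a range of 30 nM to 300 nM. The expected step is a 1.4-fold lower number from compound 3 to compound 4 (0.16 log units; within the scatter).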

Compound 4, inhibition constant: 130 nM
The estimate for compound 4 lay 1.4-fold (0.16 log units) below the measured number; the range from low to high includes it.
By their numbers in this assay, from the lowest: compounds 1 and 2 (each within the scatter of the next); then compounds 3 and 4 (each within the scatter of the next).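

The exchange of phenyl for phenoxy on a saturated chain carbon bound to an aromatic carbon gave no change at the digits printed from compound 3 to compound 4 (within the scatter) in this assay, so the hydrogen-bond acceptor counted on phenoxy brought no recovery of the lower numbers. The gap to the azoles stayed as it was for phenyl, with an 8.1-fold higher number from compound 2 to compound 4 (0.91 log units; beyond the scatter) and an 11-fold higher number from compound 1 to compound 4 (1.03 log units; beyond the scatter). Among the four groups at this place, only 1H-pyrazol-1-yl and 1H-imidazol-1-yl give the lower numbers, while two groups that each carry a six-membered aromatic ring of carbon only sit together at the higher end.

Open, going by these compounds, is whether a triazole or a simple amine on this carbon would fall with the azoles or with phenyl and phenoxy. Nothing shown gives a measured reason for the gap between these groups.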